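The source may report more compounds than this note shows. Statements on the series, on what has been measured and on what is new or still open speak of the compounds shown alone.

Among the measured compounds shown here, compound 2 `C=CCn1c(=O)/c(=C\c2ccccc2OC)[nH]c(=O)/c1=C\c1ccccc1OC` and compound 1 `C=CCn1c(=O)/c(=C\c2cccc(F)c2)[nH]c(=O)/c1=C\c1ccccc1OC` are the two measured members. In a functional assay on HeLa cells (Homo sapiens) for cytotoxicity, read by CCK-8 assay, with a stated time of 72 h (a higher number here means a weaker inhibitor, a lower number a stronger inhibitor), compound 2 gives 6900 nM, while compound 1 gives 9100 nM, the two separated only by a 1.3-fold lower number from compound 1 to compound 2 (0.12 log units; within the scatter), within the scatter. Compound 3 `C=CCn1c(=O)/c(=C\c2cccc(C)c2)[nH]c(=O)/c1=C\c1ccccc1OC` differs from compound 2 by 3-methylphenyl in place of 2-methoxyphenyl on a double-bonded chain carbon bound to an aromatic carbon. For the measured compounds named here, the one measured step at this position, a 1.3-fold lower number from compound 1 to compound 2 (0.12 log units; within the scatter), was within the scatter, and compound 3 carries 3-methylphenyl where compound 1 carried 3-fluorophenyl, so no step beyond the scatter is expected in this assay, with a 1.2-fold higher number from compound 2 to compound 3 (0.06 log units; within the scatter). Compound 3 is estimated at 8000 nM, with a range from 4000 nM to 16000 nM.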

Compound 3, half-maximal inhibitory concentration: 19300 nM
Beside the measured number, compound 3's estimate is 2.4-fold (0.38 log units) below it; the measured number lies above the stated range.
By their numbers in this assay, from the lowest: compounds 2 and 1 (each within the scatter of the next); then compound 3.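

In this assay this position now shows steps beyond the scatter: there is a 2.8-fold higher number from compound 2 to compound 3 (0.45 log units; beyond the scatter) and also a 2.1-fold higher number from compound 1 to compound 3 (0.33 log units; beyond the scatter) with methyl in place of fluoro on an aromatic carbon. The position is therefore not indifferent to the group it carries, which the earlier pair alone could not show, and among these compounds only 3-methylphenyl separates from the others. Nothing measured here accounts for this rise. Open, from the compounds shown here alone, is whether an amine, a carboxylic acid or a longer chain on this aromatic ring would move the number further in either direction.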